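A few compounds are considered here, and "the series" means these few. Any claim that something is new, unique, unknown or untested is made for them only; others in the source may bear on it.

Compound 1 `O=C(CCCCCC(=O)Nc1ccc(O)c(C(=O)Nc2ccccc2)c1)NO`: in a functional assay on HL-60 cells (Homo sapiens) for antiproliferative activity, read by MTT assay, with a stated time of 48 h (a lower number here means a stronger inhibitor, a higher number a weaker inhibitor), compound 1 gives 20300 nM.
Compound 2 `O=C(CCCCCC(=O)Nc1ccc(O)c(C(=O)Nc2ccc(F)c(Cl)c2)c1)NO`: compound 2 gives > 100000 nM, which is a limit of this assay and not a number.
Compound 3 `C#Cc1cccc(NC(=O)c2cc(NC(=O)CCCCCC(=O)NO)ccc2O)c1`: compound 3 gives > 100000 nM, again a limit of this assay rather than a number.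

Among the measured compounds shown here, compound 1 thus holds the only real number among the three; the other two sit at the limit of > 100000 nM in this assay, at which 2 of the 3 values shown sit. Compound 4 `O=C(CCCCCC(=O)Nc1ccc(O)c(C(=O)Nc2ccc(Cl)c(Cl)c2)c1)NO` has not been measured. It differs from compound 1 by 3,4-dichlorophenyl in place of phenyl on an amide-type nitrogen. The nearest measured step is an at least 4.9-fold higher number from compound 1 to compound 2 (0.69 log units; beyond the scatter), where 3-chloro-4-fluorophenyl replaced the same phenyl; the step of an at least 4.9-fold higher number from compound 1 to compound 3 (0.69 log units; beyond the scatter) points the same way. A step of at least similar size, toward a higher number, is therefore expected: a 4.9-fold higher number from compound 1 to compound 4 (0.69 log units; beyond the scatter). Compound 4 is estimated at 100000 nM, within 30000 nM to 300000 nM.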

Compound 4, half-maximal inhibitory concentration: > 100000 nM
Compound 4: a limit, no number (the forecaster's own chance of this, stated with the estimate: 65%); the middle value sits exactly at the limit.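

On the amide-type nitrogen, 3,4-dichlorophenyl in place of phenyl gives an at least 4.9-fold higher number from compound 1 to compound 4 (0.69 log units; beyond the scatter) in this assay, so a third substituted ring goes the same way as the two before it. Among the compounds shown, only the unsubstituted phenyl of compound 1 gives a number. The steps among compound 2, compound 3 and compound 4 cannot be read, because all three share one limit: the limit of > 100000 nM in this assay, at which 3 of the 4 values shown sit.

Still open, on these data alone, is whether a single fluoro, a methoxy or an amine on that phenyl would give a number. As far as these compounds go, the order of compound 2, compound 3 and compound 4 also stays unknown.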